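A few compounds are considered here, and "the series" means these few. Any claim that something is new, unique, unknown or untested is made for them only; others in the source may bear on it.

Measured in an assay on CHO-K1 cells for antagonist activity at transient receptor potential cation channel subfamily V member 1 (Homo sapiens), read by FLIPR and calcium flux, with a stated time of 6 min; a higher number here means a weaker inhibitor, a lower number a stronger inhibitor:

compound 1 `O=C(NCc1cc(C(F)(F)F)nn1-c1ccc(Cl)cc1)Nc1cccc2[nH]ncc12` gives 2.5 nM
compound 2 `Cn1ncc2c(NC(=O)NCc3cc(C(F)(F)F)nn3-c3cccc(C(F)(F)F)c3)cccc21` gives 1.4 nM

Compound 2 and compound 1 sit within the usual scatter of one another in this assay; no order between the two can be read from these numbers. Among the measured compounds shown here, the two also differ in more than one place, so no single step between them is known.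

Compound 3 `Cn1ncc2c(NC(=O)NCc3cc(C(F)(F)F)nn3-c3ccc(Cl)cc3)cccc21` is not yet measured. It carries the change (4-chlorophenyl in place of 3-(trifluoromethyl)phenyl on an aromatic nitrogen). For the measured compounds named here, the group that enters is the one compound 1 already carries on the same nitrogen, and compound 1 gives 2.5 nM in this assay, a number within the scatter of compound 2. On that basis no step beyond the scatter is expected in either direction, so the estimate for compound 3 in this assay is 2 nM, within 0.8 nM to 5 nM. This expectation corresponds to a step of a 1.4-fold higher number from compound 2 to compound 3 (0.15 log units; within the scatter).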

Compound 3, inhibition constant: 2.7 nM
The estimate for compound 3 lay 1.4-fold (0.13 log units) below the measured number, and the stated range covers the measured number.
By their numbers in this assay, from the lowest: compounds 2, 1 and 3 (each within the scatter of the next).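

In this assay, 4-chlorophenyl in place of 3-(trifluoromethyl)phenyl on the aromatic nitrogen of the five-membered ring gives a 1.9-fold higher number from compound 2 to compound 3 (0.29 log units; within the scatter), so this position takes either aryl group without a step beyond the scatter when the methyl group is present. Methyl in place of hydrogen on the other aromatic nitrogen gives a 1.1-fold higher number from compound 1 to compound 3 (0.03 log units; within the scatter), so with 4-chlorophenyl present, that hydrogen can be replaced without a step beyond the scatter. No supporting data bear on either result.

Still open, as far as these compounds go, is whether the aryl position would stay within the scatter with an amine or a carboxylic acid on the phenyl ring in place of chlorine. Also open, from the compounds shown here alone, is whether an ethyl group or a longer chain in place of methyl would do the same.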